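The compounds below may be only part of what the source reports. "The series", "measured", "known", "first", "only" and "open" are said of these compounds alone.

Measured in a functional assay on HT-29 cells (Homo sapiens) for inhibition, read by sulforhodamine B assay, with a stated time of 48 h; on this read-out higher numbers stand for weaker inhibition of growth and lower numbers for stronger inhibition of growth:
- Compound 1 `COc1ccc(-c2c(CNC(C)(C)C)c(C(=O)O)nn2-c2ccccc2)cc1`: > 659000 nM (a limit)
- Compound 2 `CC(C)(C)NCc1c(C(=O)O)nn(-c2ccc(Cl)cc2)c1-c1ccc(Cl)cc1`: > 599000 nM (a limit)
- Compound 3 `Cc1ccc(-c2c(CNC(C)(C)C)c(C(=O)O)nn2-c2ccc(Cl)cc2)cc1`: > 629000 nM (a limit)

None of these three results is a true number. Compound 3 stands only at a limit, > 629000 nM, and the other two compounds offer nothing firmer to rank it against.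

Compound 4 `COc1ccc(-c2c(CNC(C)(C)C)c(C(=O)O)nn2-c2ccc(Cl)cc2)cc1` differs from compound 3 by one change, methoxy in place of methyl on an aromatic carbon, para to a large group. Among the compounds with values here, the one measured step that bears on this is a step that the two limits leave unreadable from compound 2 to compound 3, with methyl in place of chloro at that same kind of carbon, so it gives no size to build on. Compound 1 already carries the 4-methoxyphenyl group, and it also reached only a limit, > 659000 nM.

No growth inhibition has been seen in this series, so no shift beyond the scatter is expected in this assay, in either direction. The estimated change is an at least 1.0-fold lower number from compound 3 to compound 4 (0.02 log units; that floor lies within the scatter). For compound 4 the expected value is 600000 nM, with an estimated range of 350000 nM to 900000 nM, and it will most likely be reported as a limit again.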

Compound 4, concentration for 50% growth inhibition: > 605000 nM
Compound 4: only a limit was reported; the forecaster's own chance of this, stated with the estimate: 90%; middle value at least 1.0-fold (0.00 log units) from the limit.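

In this assay compound 4 gives > 605000 nM, which is a limit. Within the data shown here, compound 1, compound 2 and compound 3 are also limits, so no step to compound 4 can be read. The compounds shown leave open whether methoxy, methyl and chloro differ at all in this assay.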